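Returning to an open chain at the oxadiazole of compound 3

The compounds below may be only part of what the source reports. "The series", "measured", "known", "first", "only" and "open" are said of these compounds alone.

Measured so far in an assay on HeLa cells for inhibition of sphingosine-1-phosphate transporter SPNS2 (Mus musculus), read by LC-MS, tested at 2 uM; a lower number here means less inhibition, a higher number more inhibition at the concentration tested (going by the name of the read-out):
- compound 1, `CCCCCCCCCCc1ccc(-c2noc(CCCCN)n2)cc1`: 55%
- compound 2, `CCCCCCCCCCc1ccc(-c2noc(C3CCNC3)n2)cc1`: 26%
- compound 3, `CCCCCCCCCCc1ccc(-c2noc([C@H]3CCCN3)n2)cc1`: 12%

All three share one core and differ only in the group on the aromatic carbon that sits between the ring nitrogen and the ring oxygen. Compound 3 gives the lowest number of the three in this assay: compound 2 stands higher by a number 14 percentage points lower from compound 2 to compound 3 (beyond the scatter) read backwards, and compound 1 higher still, as a number 43 percentage points lower from compound 1 to compound 3 (beyond the scatter) shows.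

Compound 4, `CCCCCCCCCCc1ccc(-c2noc(CC(O)CN(C)C)n2)cc1`, is the next step: 3-(dimethylamino)-2-hydroxypropyl in place of pyrrolidin-2-yl on an aromatic carbon The two steps that bear on it both run from the open 4-aminobutyl chain of compound 1 into a ring, and both lowered inhibition, a number 29 percentage points lower from compound 1 to compound 2 (beyond the scatter) and a number 43 percentage points lower from compound 1 to compound 3 (beyond the scatter). Within the data shown here, the change to compound 4 goes the other way, from a ring back to a group with no ring, though the amine is now dimethylated and a hydroxyl is added, for which no measured step exists. A rise beyond the scatter is therefore expected, a number 28 percentage points higher from compound 3 to compound 4 (beyond the scatter), landing short of compound 1 given the uncertainty. The estimate for compound 4 in this assay is 40%, between 15% and 65%.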

Compound 4, a percentage reported as inhibition, at one concentration (the size of the read-out at that concentration, not a potency): 61%
Compound 4: middle estimate off by 21 percentage points, on the low side; measured number inside the range.
By their numbers in this assay, from the lowest: compound 3; then compound 2; then compounds 1 and 4 (each within the scatter of the next).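

In this assay, replacing the pyrrolidin-2-yl ring with the open 3-(dimethylamino)-2-hydroxypropyl group gives a number 49 percentage points higher from compound 3 to compound 4 (beyond the scatter), and replacing the pyrrolidin-3-yl ring with the same group gives a number 35 percentage points higher from compound 2 to compound 4 (beyond the scatter), so both ring compounds now sit well below a second open chain, not only below the 4-aminobutyl chain. The two open chains cannot be told apart, with a number 6 percentage points higher from compound 1 to compound 4 (within the scatter), which shows that this position keeps its level of inhibition when the simple terminal amine gives way to a dimethylamino group and a hydroxyl is added to the chain. Nothing available here explains the gap between the open chains and the rings.

From the compounds shown here alone, compound 4 brings the hydroxyl and the dimethylamino group together, so the share of each remains unknown, and the same chain without the hydroxyl would be needed to separate them. Going by these compounds, it also remains open whether a chain ending in a carboxylic acid instead of an amine, or a longer chain, would hold this level, and how any of these readings at a single concentration would translate into potency.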